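A few compounds are considered here, and "the series" means these few. Any claim that something is new, unique, unknown or untested is made for them only; others in the source may bear on it.

Compound 1 `C/C(=N\NC(N)=S)c1ccc2[nH]c(-c3ccc(C(F)(F)F)cc3)nc2c1` and compound 2 `COc1ccc(-c2nc3cc(/C(C)=N/NC(N)=S)ccc3[nH]2)cc1` share one core and differ in a single place, (methoxy in place of trifluoromethyl on an aromatic carbon). In an ADME assay on BHK-21 cells (Mesocricetus auratus) for cytotoxicity, read by MTT assay (on this read-out lower numbers stand for higher toxicity in this test and higher numbers for lower toxicity in this test), compound 1 gives 5000 nM, while compound 2 gives 13000 nM, and the change brought a 2.6-fold higher number from compound 1 to compound 2 (0.41 log units; beyond the scatter). Compound 3 `CC(=O)c1ccc2c(c1)nc(-c1ccc(C(F)(F)F)cc1)n2C1CCCCC1` gives 33000 nM in this assay, the highest number among the three measured compounds. How the core of compound 3 differs from that of compound 1 is not broken down here. Compound 4 `COc1ccc(-c2nc3cc(C(C)=O)ccc3n2C2CCCCC2)cc1` has not yet been measured. It is related to compound 3 by methoxy in place of trifluoromethyl on an aromatic carbon, the same change that separates compound 1 from compound 2, so this change occurs twice among the compounds shown. Going by the values given here, since the only measured example of it gave a 2.6-fold higher number from compound 1 to compound 2 (0.41 log units; beyond the scatter), a step of similar size is expected in this assay, namely a 2.4-fold higher number from compound 3 to compound 4 (0.38 log units; beyond the scatter). That expectation rests on a single pair, and the core of compound 3 differs from that of compound 1 in more than one place, which makes the transfer uncertain. Compound 4 is therefore expected to give about 80000 nM in this assay, with a likely range from 35000 nM to 200000 nM.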

Compound 4, half-maximal cytotoxic concentration: > 100000 nM
Compound 4: a limit, no number (the forecaster's own chance of this, stated with the estimate: 25%); middle value at least 1.2-fold (0.09 log units) from the limit.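

In this assay, methoxy in place of trifluoromethyl on the core of compound 3 gives an at least 3.0-fold higher number from compound 3 to compound 4 (0.48 log units; beyond the scatter), so the number rises on both cores shown: the same change on two cores in this assay, a 2.6-fold higher number (0.41 log units; beyond the scatter) from compound 1 to compound 2 and an at least 3.0-fold higher number (0.48 log units; beyond the scatter) from compound 3 to compound 4; the limit leaves it open whether they differ. Compound 4 gives > 100000 nM, which is a limit of the assay and not a number: the limit of > 100000 nM in this assay, at which 1 of the 4 values shown sits. For this series, the two cores show that the direction of the change carries from one core to the other, but they do not show that its size carries over, and two cores alone support no rule for any further core.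

The compounds shown leave open how large the step on the core of compound 3 really is, as the result for compound 4 is a limit. They also leave open how this assay would read with a nitrile, an amine or a carboxylic acid in the same place on the aromatic ring, on either core.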